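This account rests on a few compounds, and the source may have more. Where it says the series, first, only, none or still open, it means among the compounds named here.

Measured so far in a physicochemical assay for solubility, at pH 7; on this read-out higher numbers stand for higher solubility and lower numbers for lower solubility:
compound 1 `CC(C)(C)C(=O)N1Cc2c(NC(=O)c3ccncc3)n[nH]c2C1(C)C` — compound 1 gives 205000 nM
compound 2 `CN1CCC(C(=O)N2Cc3c(NC(=O)C4CCC4)n[nH]c3C2(C)C)CC1` — compound 2 gives > 225000 nM, a limit of the assay
compound 3 `CN1CCC(C(=O)Nc2n[nH]c3c2CN(C(=O)C(C)(C)C)C3(C)C)CC1` — compound 3 gives > 225000 nM, a limit of the assay

Compound 2 stands at the upper limit of this assay, the point at which two of the three values sit (the limit of > 225000 nM in this assay, at which 2 of the 3 values shown sit). Compound 4 `CN1CCC(C(=O)N2Cc3c(NC(=O)c4ccco4)n[nH]c3C2(C)C)CC1` differs from compound 2 in one place: furan-2-yl in place of cyclobutyl on a carbonyl carbon. Within the data shown here, the one measured step that touches the same position is an at least 1.0-fold higher number from compound 1 to compound 3 (0.04 log units; that floor lies within the scatter), which exchanges an aromatic ring for a saturated one on a carbonyl carbon, the reverse sense of the change here, and it lay within the scatter; compound 1, carrying the aromatic pyridin-4-yl group, gives 205000 nM. With every measured value at or near that limit, no step beyond the scatter is expected in this assay in either direction; the expected step is an at least 1.1-fold lower number from compound 2 to compound 4 (0.07 log units; that floor lies within the scatter). Compound 4 is therefore estimated at 190000 nM, with a range from 90000 nM to 225000 nM, and a fair chance that only a limit is returned.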

Compound 4, solubility: > 225000 nM
Compound 4: no number, only a limit (the forecaster's own chance of this, stated with the estimate: 45%); middle value at least 1.1-fold (0.07 log units) away from the limit.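

In this assay, compound 2 and compound 4 each return only a limit, so no step can be read for furan-2-yl in place of cyclobutyl: the limit of > 225000 nM in this assay, at which 3 of the 4 values shown sit.

The compounds shown leave open whether compound 2 and compound 4 differ at all in this assay, and by how much.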